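The source may report more compounds than this note shows. Statements on the series, on what has been measured and on what is new or still open speak of the compounds shown alone.

Working notes on the series. The shared core carries one variable substituent on a phenyl ring. Compound 1 `Cc1cccc(-c2n[nH]cc2N2CCCNCC2)c1` gives 3290 nM in an assay on isolated protein for binding affinity to 5-hydroxytryptamine receptor 1D (Homo sapiens); a lower number here means a stronger inhibitor, a higher number a weaker inhibitor. For compound 2 `COc1ccccc1-c1n[nH]cc1N1CCCNCC1` this assay reports only a limit, > 10000 nM. For compound 3 `COc1cccc(-c2n[nH]cc2N2CCCNCC2)c1` this assay likewise reports only a limit, > 10000 nM. The step of an at least 3.0-fold higher number from compound 1 to compound 3 (0.48 log units; beyond the scatter) lies beyond the scatter. Compound 3 thus stands at the limit of > 10000 nM in this assay, at which 2 of the 3 values shown sit, with no number of its own. Compound 4 `c1ccc(-c2n[nH]cc2N2CCCNCC2)cc1` differs from compound 3 by hydrogen in place of methoxy on an aromatic carbon. On these data alone, only the methyl-to-methoxy step bears on this, and it weakened binding; hydrogen against methyl at this position is untested. Compound 4 is therefore expected to give 5000 nM (range 1500 nM to 15000 nM). The expected step is an at least 2.0-fold lower number from compound 3 to compound 4 (0.30 log units; that floor lies within the scatter).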

Compound 4, inhibition constant: > 10000 nM
Compound 4 was reported as a limit (the forecaster's own chance of this, stated with the estimate: 40%); middle value at least 2.0-fold (0.30 log units) away from the limit.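

Taking the substituent away does not recover binding: in this assay, compound 4 also reports only a limit, > 10000 nM. Hydrogen in place of methyl gives an at least 3.0-fold higher number from compound 1 to compound 4 (0.48 log units; beyond the scatter), so at this position methyl is the only group shown with a measured number, and both hydrogen and methoxy fall short of it. The steps from compound 2 and compound 3 to compound 4 cannot be read, as both ends of each are limits.

On these data alone, whether an ethyl group, a chlorine atom or an amine at this position would give a lower number than methyl remains open. As far as these compounds go, the order among compound 2, compound 3 and compound 4 also remains open.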